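A few compounds are considered here, and "the series" means these few. Any claim that something is new, unique, unknown or untested is made for them only; others in the source may bear on it.

The compounds measured so far:

Compound 1, `Cc1cccc(CN2CC=C(CCC(=O)NO)C2=O)c1`: in a functional assay on NCI-H23 cells (Homo sapiens) for inhibition, read by sulforhodamine B assay (on this read-out higher numbers stand for weaker inhibition of growth and lower numbers for stronger inhibition of growth), compound 1 gives 2500 nM.
Compound 2, `Cc1ccc(CN2CC=C(CCC(=O)NO)C2=O)cc1`: in this assay compound 2 gives 2500 nM.
Compound 3, `CC(C)(C)c1ccc(CCCN2CC=C(CCC(=O)NO)C2=O)cc1`: in this assay compound 3 gives 2520 nM.

All three share the same hydroxamic acid core and differ only in the group carried on the ring nitrogen. On the numbers shown, compound 2 sits level with compound 1 at the digits given, and its value and that of compound 3 lie within the usual scatter of each other, so the three numbers cannot be put in any order: they read as one and the same level of growth inhibition.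

The next compound, compound 4, `O=C(CCC1=CCN(Cc2ccc(F)cc2)C1=O)NO`, is compound 2 with one substitution: fluoro in place of methyl on an aromatic carbon.

Going by the values given here, no step between two measured compounds is available for this particular swap. What the measured set does show is that three quite different groups on the ring nitrogen all landed at the same number. On that basis the expected step in this assay is none beyond the scatter, in neither direction. Compound 4 is therefore estimated at 2500 nM, with a range from 1200 nM to 5200 nM. That estimate corresponds to an expected step of no change at the digits printed from compound 2 to compound 4 (within the scatter).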

Compound 4, concentration for 50% growth inhibition: 4670 nM
Compound 4: middle estimate off by 1.9-fold (0.27 log units), on the low side; the measured number falls inside the stated range.
By their numbers in this assay, from the lowest: compounds 1, 2, 3 and 4 (each within the scatter of the next).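

In this assay, going by these compounds alone, fluoro in place of methyl on an aromatic carbon, para to a large group, gives the first step that can be read at this place on the ring (a 1.9-fold higher number from compound 2 to compound 4 (0.27 log units; within the scatter)). The step is larger than the differences among the earlier numbers, but it stays within the scatter, so this single pair does not show that the swap changes growth inhibition; the two compounds have to be read as one level, and the methyl cannot be called better or worse than the fluoro. Nothing measured here on the compounds themselves offers an explanation for the size of this step.

Still open, as far as these compounds go, is whether a group that differs more from methyl at this same place, such as an amine, a methoxy, a carboxylic acid or a longer chain, would give a step beyond the scatter. Also open, from the compounds shown here alone, is whether fluoro in place of the methyl of compound 1 would give a step of similar size, which would show whether the reading from this one pair holds elsewhere on the ring.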